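The source may hold more compounds than are shown below. What is called first, only, known or untested is meant among the compounds shown, and "the series" means these compounds.

Working notes on the series. Compound 3 `CC(C)c1ccc(Nc2nc(SCc3cn(CC(=O)NC(=O)Nc4ccccn4)nn3)nc(-c3ccc(Br)cc3)c2C#N)cc1` gives 15600 nM in a functional assay on MGC-803 cells (Homo sapiens) for inhibition, read by MTT assay, with a stated time of 72 h; on this read-out lower numbers stand for stronger inhibition and higher numbers for weaker inhibition. Compound 1 `CC(C)c1ccc(Nc2nc(SCc3cn(CC(=O)NC(=O)Nc4ccccn4)nn3)nc(-c3ccc(C(C)C)cc3)c2C#N)cc1` gives 15800 nM in this assay, and compound 2 `Cc1ccc(-c2nc(SCc3cn(CC(=O)NC(=O)Nc4ccccn4)nn3)nc(Nc3ccc(C(C)C)cc3)c2C#N)cc1` gives 19300 nM in this assay. Compound 3 has the lowest of the three numbers, yet its separation from the others is small. The step of a 1.0-fold lower number from compound 1 to compound 3 (0.01 log units; within the scatter) and the step of a 1.2-fold lower number from compound 2 to compound 3 (0.09 log units; within the scatter) both lie within the scatter, as does a 1.2-fold higher number from compound 1 to compound 2 (0.09 log units; within the scatter), so the three compounds cannot be ordered against each other.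

Compound 4 `CC(C)c1ccc(Nc2nc(SCc3cn(CC(=O)NC(=O)Nc4ccccn4)nn3)nc(-c3ccc(Cl)cc3)c2C#N)cc1` differs from compound 3 by chloro in place of bromo on an aromatic carbon. The three measured steps all vary the group on this same aromatic carbon, and none of them moved the number beyond the scatter, so a further swap at the same place, from one halogen to another, is expected to give no step beyond the scatter in this assay either. The expected step is no change at the digits printed from compound 3 to compound 4 (within the scatter). For compound 4 the estimated value in this assay is 15600 nM, with a range from 8000 nM to 30000 nM.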

Compound 4, half-maximal inhibitory concentration: 16900 nM
Estimate against measurement, compound 4: 1.1-fold (0.03 log units) below, within the range that was stated.
By their numbers in this assay, from the lowest: compounds 3, 1, 4 and 2 (each within the scatter of the next).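

Among these compounds, the change from 4-bromophenyl to 4-chlorophenyl gives a 1.1-fold higher number from compound 3 to compound 4 (0.03 log units; within the scatter) in this assay, the first direct halogen-to-halogen comparison at this place. Chloro also stays level with the two alkyl groups, with a 1.1-fold lower number from compound 2 to compound 4 (0.06 log units; within the scatter) against methyl and a 1.1-fold higher number from compound 1 to compound 4 (0.03 log units; within the scatter) against isopropyl, so isopropyl, methyl, bromo and chloro on this aromatic carbon all lie within the scatter of one another. No measurement at hand accounts for this flat response.

On these data alone, whether an amine, a carboxylic acid or a longer chain on this aromatic carbon would give a step beyond the scatter remains open. Also open, as far as these compounds go, is whether replacing the isopropyl that all four compounds keep elsewhere on the shared core, for example with a methoxy group, would move the number.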